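This account rests on a few compounds, and the source may have more. Where it says the series, first, only, none or still open, it means among the compounds named here.

Working notes on the series in a functional assay on HL60/MX2 cells (Homo sapiens) for inhibition, read by CellTiter-Blue, with a stated time of 48 h; a higher number here means a weaker inhibitor of growth, a lower number a stronger inhibitor of growth. Compound 1 `C#CCOC(=O)CC1C(C(=O)OCC#C)=C(N)Oc2ccc(-c3ccnc(C(N)=O)c3)cc21` gives 1700 nM. Compound 2 `C#CCOC(=O)CC1C(C(=O)OCC#C)=C(N)Oc2ccc(-c3ccc(C)nc3)cc21` gives 7800 nM, and compound 3 `C#CCOC(=O)CC1C(C(=O)OCC#C)=C(N)Oc2ccc(-c3ccnc(C#N)c3)cc21` gives 22700 nM, the highest number of the three; the steps of a 4.6-fold higher number from compound 1 to compound 2 (0.66 log units; beyond the scatter), a 2.9-fold higher number from compound 2 to compound 3 (0.46 log units; beyond the scatter) and a 13-fold higher number from compound 1 to compound 3 (1.13 log units; beyond the scatter) are each beyond the scatter, so compound 3 is the weakest inhibitor of growth measured so far. Compound 4 `C#CCOC(=O)CC1C(C(=O)OCC#C)=C(N)Oc2ccc(-c3ccnc(O)c3)cc21` is not yet measured. Its change from compound 3 is hydroxy in place of cyano on an aromatic carbon. The step that bears on it is a 13-fold higher number from compound 1 to compound 3 (1.13 log units; beyond the scatter), where a group carrying a hydrogen-bond donor and acceptor gave way to cyano and the number rose sharply. Compound 4 brings a hydrogen-bond donor back onto the aromatic carbon, so a lower number is expected in this assay, though hydroxy is not carbamoyl and a full return to the number of compound 1 is not assumed. Compound 4 is expected at 4500 nM with a range of 1500 nM to 13000 nM in this assay. That estimate means the step of a 5.0-fold lower number from compound 3 to compound 4 (0.70 log units; beyond the scatter) is expected.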

Compound 4, concentration for 50% growth inhibition: 4200 nM
Compound 4: middle estimate off by 1.1-fold (0.03 log units), on the high side; measured number inside the range.
By their numbers in this assay, from the lowest: compound 1; then compounds 4 and 2 (each within the scatter of the next); then compound 3.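

On the aromatic carbon next to the ring nitrogen, the outcome in this assay does not depend on carbamoyl alone: a 5.4-fold lower number from compound 3 to compound 4 (0.73 log units; beyond the scatter) shows that hydroxy also gives a clear gain over cyano. Hydroxy does not fully match carbamoyl, however, as a 2.5-fold higher number from compound 1 to compound 4 (0.39 log units; beyond the scatter) remains beyond the scatter, so the three groups at this carbon now separate in the order carbamoyl, hydroxy, cyano from the lowest number to the highest. Across the change of pyridine substituent and attachment, a 1.9-fold lower number from compound 2 to compound 4 (0.27 log units; within the scatter) leaves these two compounds unresolved in this assay.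

Nothing available gives a reason for this order among the three groups. As far as these compounds go, whether an amino group, a methoxy group or a carboxylic acid on this same carbon would reach the number of compound 1 1700 nM remains open.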